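Replacing the 4-methoxyphenyl group of compound 2

A few compounds are considered here, and "the series" means these few. Any claim that something is new, unique, unknown or untested is made for them only; others in the source may bear on it.

Measured in a functional assay on HCT-116 cells (Homo sapiens) for cytotoxicity, read by MTT assay, with a stated time of 48 h; a higher number here means a weaker inhibitor, a lower number a stronger inhibitor:
- compound 1 `Cc1nc2c3ccccc3ccc2c2nc3c(ccc4ccccc43)c(-c3nccnc3N)c12`: 3560 nM
- compound 2 `COc1ccc(-c2c3ccc4ccccc4c3nc3c2c(C)nc2c4ccccc4ccc32)cc1`: > 80000 nM (a limit)

Compound 2 stands at the limit of > 80000 nM in this assay, at which 1 of the 2 values shown sits, so its place is known only as a limit.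

Compound 3 `Cc1nc2c3ccccc3ccc2c2nc3c(ccc4ccccc43)c(-c3cc([N+](=O)[O-])ccc3N)c12` carries 2-amino-5-nitrophenyl in place of 4-methoxyphenyl on an aromatic carbon. Within the data shown here, the only measured step at this place is an at least 22-fold higher number from compound 1 to compound 2 (1.35 log units; beyond the scatter), with 4-methoxyphenyl in place of 3-aminopyrazin-2-yl. Compound 3 also lacks 4-methoxyphenyl, so a large step to a lower number in this assay is expected, towards compound 1. The expected change is an at least 8.8-fold lower number from compound 2 to compound 3 (0.94 log units; beyond the scatter). For compound 3 the estimated value is 9000 nM, with an expected range of 2000 nM to 40000 nM.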

Compound 3, half-maximal inhibitory concentration: 6010 nM
Estimate against measurement, compound 3: 1.5-fold (0.18 log units) above, within the range that was stated.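

In this assay, a second group at this place gives a measurable value, and it has a ring of carbon only: an at least 13-fold lower number from compound 2 to compound 3 (1.12 log units; beyond the scatter). The ring nitrogens of 3-aminopyrazin-2-yl are therefore not required, as 2-amino-5-nitrophenyl shows a 1.7-fold higher number from compound 1 to compound 3 (0.23 log units; within the scatter). The size of the first step is open-ended, as compound 2 is known only as a limit: the limit of > 80000 nM in this assay, at which 1 of the 3 values shown sits.

Compound 3 differs from compound 2 in both the amine and the nitro group, so the compounds shown do not separate their contributions. A plain 2-aminophenyl group, or a carboxylic acid in place of the nitro group, would address this.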